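The compounds below may be only part of what the source reports. "The series", "measured", "known", "first", "only" and "open" are said of these compounds alone.

Measured in an assay for binding affinity to 5-hydroxytryptamine receptor 1F (Homo sapiens), read by radioligand binding; on this read-out higher numbers stand for weaker inhibition and lower numbers for stronger inhibition:
compound 1 `COc1ccccc1C(=O)Nc1ccc2[nH]cc(C3CCN(C)CC3)c2n1` gives 20 nM
compound 2 `CN1CCC(c2c[nH]c3ccc(NC(=O)c4ccc([N+](=O)[O-])cc4)nc23)CC1` gives 7.7 nM
compound 3 `CN1CCC(c2c[nH]c3ccc(NC(=O)c4cccs4)nc23)CC1` gives 7.1 nM

Compound 3 and compound 2 lie within the scatter of each other, the step being a 1.1-fold lower number from compound 2 to compound 3 (0.04 log units; within the scatter). Both stand apart from compound 1: a 2.8-fold lower number from compound 1 to compound 3 (0.45 log units; beyond the scatter) and a 2.6-fold lower number from compound 1 to compound 2 (0.41 log units; beyond the scatter), each a modest step.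

Compound 4 `CCCC(=O)Nc1ccc2[nH]cc(C3CCN(C)CC3)c2n1` differs from compound 3 in one place: propyl in place of thiophen-2-yl on a carbonyl carbon. Within the data shown here, every measured step on this carbonyl carbon swaps one ring for another ring; none exchanges a ring for a chain, so no measured step bears directly on the change to compound 4. What the three measured numbers do show is that varied groups on this carbonyl carbon all stay within a narrow band of this assay. Among the measured compounds shown here, with no direct precedent, the expectation for compound 4 is a step of a 3.5-fold higher number from compound 3 to compound 4 (0.55 log units; beyond the scatter), towards a somewhat higher number, with a wide margin on both sides. The estimate for compound 4 is 25 nM, with a range from 7 nM to 90 nM.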

Compound 4, inhibition constant: 6.9 nM
The estimate for compound 4 lay 3.6-fold (0.56 log units) above the measured number; the whole stated range lies above it.
By their numbers in this assay, from the lowest: compounds 4, 3 and 2 (each within the scatter of the next); then compound 1.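

In this assay this carbonyl carbon accepts a chain as well as a ring: the change to propyl gives a 1.0-fold lower number from compound 3 to compound 4 (0.01 log units; within the scatter), and the same change gives a 1.1-fold lower number from compound 2 to compound 4 (0.05 log units; within the scatter). A ring at this position is therefore not required to reach the numbers of compound 2 and compound 3, at least where propyl is the replacement. The gap to the 2-methoxyphenyl amide remains, with a 2.9-fold lower number from compound 1 to compound 4 (0.46 log units; beyond the scatter), so among these four compounds only compound 1 stands apart, and nothing at hand explains why the chain and the two rings read alike.

Open, on these data alone, is whether a longer chain, a branched chain such as tert-butyl, or a chain carrying an amine or a carboxylic acid stays in this band. Also open, as far as these compounds go, is whether unsubstituted phenyl reads with compound 1 or with the other three.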